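From 4-methylphenyl to 3-methoxyphenyl on the shared core

The source may hold more compounds than are shown below. What is called first, only, known or untested is meant among the compounds shown, and "the series" means these compounds.

Compound 1 `O=C1C=C(Nc2ccccc2F)C(=O)c2c1nc1n2[C@H]2OC[C@@H](O)[C@H]2OC1`: 3640 nM
Compound 2 `CCOc1ccc(NC2=CC(=O)c3nc4n(c3C2=O)[C@H]2OC[C@@H](O)[C@H]2OC4)cc1`: 1430 nM
Compound 3 `Cc1ccc(NC2=CC(=O)c3nc4n(c3C2=O)[C@H]2OC[C@@H](O)[C@H]2OC4)cc1`: 1660 nM

The three compounds were measured in a functional assay on MCF7 cells (Homo sapiens) for inhibition, read by sulforhodamine B assay (on this read-out higher numbers stand for weaker inhibition and lower numbers for stronger inhibition), and they differ only in the aryl group on an amine nitrogen. Compound 3 cannot be told apart from compound 2, with a 1.2-fold higher number from compound 2 to compound 3 (0.06 log units; within the scatter). Its gap to compound 1 is modest, with a 2.2-fold lower number from compound 1 to compound 3 (0.34 log units; beyond the scatter). The companion change gives a 2.5-fold lower number from compound 1 to compound 2 (0.41 log units; beyond the scatter).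

The next compound, compound 4 `COc1cccc(NC2=CC(=O)c3nc4n(c3C2=O)[C@H]2OC[C@@H](O)[C@H]2OC4)c1`, carries 3-methoxyphenyl in place of 4-methylphenyl on an amine nitrogen.

For the measured compounds named here, no measured compound carries a 3-methoxyphenyl group, so this exact change is untested. The closest evidence is the exchange of ethoxy for methyl on an aromatic carbon, with a 1.2-fold higher number from compound 2 to compound 3 (0.06 log units; within the scatter). The two larger steps, both starting from the 2-fluorophenyl group, stayed modest. A step beyond the scatter is therefore not expected in this assay, and neither direction is favoured. The expected change is a 1.1-fold higher number from compound 3 to compound 4 (0.04 log units; within the scatter). For compound 4 the estimated value is 1800 nM, with an expected range from 800 nM to 4000 nM.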

Compound 4, half-maximal inhibitory concentration: > 4000 nM
Compound 4 was reported as a limit (the forecaster's own chance of this, stated with the estimate: 2%); middle value at least 2.2-fold (0.34 log units) away from the limit.
By their numbers in this assay, from the lowest: compounds 2 and 3 (each within the scatter of the next); then compound 1. At a limit, above all of these: compound 4.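

The earlier compounds shown here suggested that the aryl group on the amine nitrogen could be exchanged with little consequence among the better members, since compounds 2 and 3 could not be told apart in this assay. Compound 4 shows that this tolerance does not extend to 3-methoxyphenyl, with an at least 2.4-fold higher number from compound 3 to compound 4 (0.38 log units; beyond the scatter) and an at least 2.7-fold higher number from compound 2 to compound 4 (0.44 log units; beyond the scatter). The remaining step is an at least 1.0-fold higher number from compound 1 to compound 4 (0.04 log units; that floor lies within the scatter), so it cannot be read as a difference. The value of compound 4 is a limit and not a number: the limit of > 4000 nM in this assay, at which 1 of the 4 values shown sits.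

The compounds shown leave open whether the weaker result goes with the methoxy group itself or with where it sits, a question that 4-methoxyphenyl and 3-methylphenyl on the same amine nitrogen would separate. They also leave open how far compound 4 lies past its limit, and how the shared core would read with an unsubstituted phenyl or with a carboxylic acid on the aryl ring.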